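Third Ring Swap in a Series Showing No Inhibition

The source may report more compounds than this note shows. Statements on the series, on what has been measured and on what is new or still open speak of the compounds shown alone.

Of the compounds shown here, three built on one shared core have been tested in an assay on CHO cells for displacement of a labelled ligand from adenosine receptor A3 (Homo sapiens), read by scintillation counting, tested at 10 uM; a higher number here means more inhibition at the concentration tested (going by the name of the read-out), a lower number less inhibition. Compound 1 `CC(C)(C)Cc1c(-c2cccnc2)sc(N)c1C(=O)c1ccc(Cl)cc1` gives 1% in this assay, compound 2 `CC(C)(C)Cc1c(-c2ccccn2)sc(N)c1C(=O)c1ccc(Cl)cc1` gives 1%, and compound 3 `CC(C)(C)Cc1c(-c2c(F)cccc2F)sc(N)c1C(=O)c1ccc(Cl)cc1` gives 1%. Compound 3 thus stands level with compounds 1 and 2 at the digits shown: the steps of no change at the digits printed from compound 1 to compound 2 (within the scatter), no change at the digits printed from compound 1 to compound 3 (within the scatter) and no change at the digits printed from compound 2 to compound 3 (within the scatter) all lie within the scatter, so none of the three ring exchanges has moved the read-out.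

Compound 4 `COc1ccccc1-c1sc(N)c(C(=O)c2ccc(Cl)cc2)c1CC(C)(C)C` differs from compound 3 in a single place: 2-methoxyphenyl in place of 2,6-difluorophenyl on an aromatic carbon. All three measured steps exchange the ring that sits on this same aromatic carbon, and each of them left inhibition unchanged, so they bear directly on the new change. Because the steps of no change at the digits printed from compound 1 to compound 2 (within the scatter), no change at the digits printed from compound 1 to compound 3 (within the scatter) and no change at the digits printed from compound 2 to compound 3 (within the scatter) all lie within the scatter, no step beyond the scatter is expected for a number 1 percentage points higher from compound 3 to compound 4 (within the scatter) in this assay. Compound 4 is therefore estimated at 2%, with a range from -8% to 14%.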

Compound 4, a percentage reported as inhibition, at one concentration (the size of the read-out at that concentration, not a potency): 1%
Beside the measured number, compound 4's estimate is 1 percentage points above it; measured number inside the range.
By their numbers in this assay, from the lowest: compounds 1, 2, 3 and 4 (each within the scatter of the next).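

The new ring gives no change at the digits printed from compound 3 to compound 4 (within the scatter) and no change at the digits printed from compound 2 to compound 4 (within the scatter) and also no change at the digits printed from compound 1 to compound 4 (within the scatter) in this assay at this position, on the aromatic carbon next to the ring sulfur. Among the compounds shown, only compound 4 carries oxygen on this ring: 2-methoxyphenyl has 1 hydrogen-bond acceptor where 2,6-difluorophenyl has 0, and both have 8 heavy atoms, yet this exchange leaves the read-out where it was. No measurement is at hand to explain this flat result.

Going by these compounds, whether a ring bearing an amine or a carboxylic acid at this position, or a longer chain in place of the ring, would move the read-out remains open. Also open, on these data alone, is whether any change to the neopentyl group, the (4-chlorophenyl)carbonyl group or the amino group would do so.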